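Hydroxamate series: fluoro in place of methyl on the aromatic ring

The source may hold more compounds than are shown below. What is called first, only, known or untested is meant among the compounds shown, and "the series" means these compounds.

Measured compounds:
compound 1, `O=C(CCC1=CCN(CCCc2ccc(Cl)cc2)C1=O)NO`, 3480 nM
compound 2, `Cc1ccc(CN2CC=C(CCC(=O)NO)C2=O)cc1`, 4620 nM
compound 3, `CC(C)(C)c1ccc(CCCN2CC=C(CCC(=O)NO)C2=O)cc1`, 3480 nM

In a functional assay on PC-3 cells (Homo sapiens) for inhibition, read by sulforhodamine B assay (a higher number here means a weaker inhibitor of growth, a lower number a stronger inhibitor of growth), compound 2 gives the highest of the three numbers, but its gaps to compound 1 and to compound 3 are both within the scatter, so the three compounds cannot be separated on these data. The step under consideration goes from compound 2 to compound 4, `O=C(CCC1=CCN(Cc2ccc(F)cc2)C1=O)NO`: fluoro in place of methyl on an aromatic carbon.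

Within the data shown here, only one measured step bears on a swap of the group on the aromatic carbon. It is no change at the digits printed from compound 1 to compound 3 (within the scatter), which exchanges one substituent for a very different one at the same kind of place without any movement beyond the scatter. Among the measured compounds shown here, nothing in the three measured compounds shows the substituent on the aromatic ring mattering in this assay, and there is no measured fluoro compound to sharpen the picture. The expectation for compound 4 is therefore a step of about a 1.1-fold lower number from compound 2 to compound 4 (0.04 log units; within the scatter), no change beyond the scatter, in either direction.

Compound 4 is estimated at 4200 nM in this assay, with a range from 2000 nM to 9000 nM.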

Compound 4, concentration for 50% growth inhibition: 5310 nM
Beside the measured number, compound 4's estimate is 1.3-fold (0.10 log units) below it; the measured number falls inside the stated range.
By their numbers in this assay, from the lowest: compounds 1, 3, 2 and 4 (each within the scatter of the next).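

In this assay, among these compounds, fluoro in place of methyl on the aromatic carbon para to a large group gives a 1.1-fold higher number from compound 2 to compound 4 (0.06 log units; within the scatter), the first direct reading of a swap on the ring of compounds 2 and 4. The earlier reading, no change at the digits printed from compound 1 to compound 3 (within the scatter), came from compounds with a different chain to the ring, so two swaps on two chains now agree, with neither moving the number beyond the scatter and no compound shown going against this. Nothing available here accounts for this flat response at the ring position.

Open is whether an amine or a carboxylic acid on this aromatic carbon would shift the number in this assay, as the groups shown so far are limited to methyl, fluoro, chloro and tert-butyl. Also open is whether the chain joining the aromatic ring to the core has any effect of its own: no pair shown differs in that chain alone.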